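A Chain Change on a Compound at the Assay Limit

The source may hold more compounds than are shown below. What is called first, only, known or untested is meant among the compounds shown, and "the series" means these compounds.

In a functional assay on SMMC-7721 cells (Homo sapiens) for antiproliferative activity, read by MTT assay, with a stated time of 48 h (a lower number here means a stronger inhibitor, a higher number a weaker inhibitor), compound 2 `Cn1cc(C2=C(c3nn(CCCn4cccc4)c4ncccc34)C(=O)NC2=O)c2ccccc21` reads > 100000 nM, which is a limit and not a number. Compound 1 `Cn1cc(C2=C(c3nn(CCCn4cncn4)c4ncccc34)C(=O)N(c3ccccc3)C2=O)c2ccccc21` reads > 100000 nM, also a limit. Compound 3 `Cn1cc(C2=C(c3nn(CCCCn4ccnc4)c4ncccc34)C(=O)NC2=O)c2ccccc21` carries (1H-imidazol-1-yl)methyl in place of 1H-pyrrol-1-yl on a saturated chain carbon, three bonds along the chain from an aromatic nitrogen. For the measured compounds named here, no measured step between compounds is available to size this change in this assay, so little movement beyond the scatter is expected. The estimated step is an at least 1.6-fold lower number from compound 2 to compound 3 (0.22 log units; that floor lies within the scatter). Compound 3 is expected at about 60000 nM, within an estimated range of 12000 nM to 150000 nM.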

Compound 3, half-maximal inhibitory concentration: 29200 nM
For compound 3 the middle estimate is 2.1-fold (0.31 log units) above the measured one; the range from low to high includes it.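

Compound 3 is the first compound shown to give a number rather than a limit in this assay, and going from 3-(1H-pyrrol-1-yl)propyl to 4-(1H-imidazol-1-yl)butyl gives an at least 3.4-fold lower number from compound 2 to compound 3 (0.53 log units; beyond the scatter). This step is only a floor, since compound 2 stands at a limit: the limit of > 100000 nM in this assay, at which 2 of the 3 values shown sit.

The step changes both the ring and the chain length, so the compounds shown do not separate the two. Going by these compounds, a 4-(1H-pyrrol-1-yl)butyl group would bear on that, and an amine at the chain end remains open too.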